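Trifluoromethoxy for carbamoyl: cytotoxicity notes from compound 1

The compounds below may be only part of what the source reports. "The series", "measured", "known", "first", "only" and "open" are said of these compounds alone.

In an ADME assay on Raji cells (Homo sapiens) for cytotoxicity, with a stated time of 72 h (on this read-out higher numbers stand for an effect only at larger amounts of compound and lower numbers for an effect already at smaller amounts), compound 1 (`Cc1cc(NC(=O)Nc2cccc(C(N)=O)c2)c2ccccc2n1`) gives > 25000 nM, which is a limit and not a number. Compound 2 (`Cc1cc(NC(=O)Nc2cnc3ccccc3c2)c2ccccc2n1`) gives > 25000 nM, also a limit. Compound 3 (`Cc1cc(NC(=O)Nc2ccc(C(=O)O)c(O)c2)c2ccccc2n1`) gives > 25000 nM, again a limit. Compound 1 therefore has no exact value and stands with the other two, as the limit of > 25000 nM in this assay, at which 3 of the 3 values shown sit, shows.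

Compound 4 (`Cc1cc(NC(=O)Nc2cccc(OC(F)(F)F)c2)c2ccccc2n1`) carries trifluoromethoxy in place of carbamoyl on an aromatic carbon. Among the compounds with values here, no measured pair shows what a single change does in this assay. The expected move is a number no higher from compound 1 to compound 4 (the limit leaves the size open), which means none beyond the scatter, and it rests only on (the limit of > 25000 nM in this assay, at which 3 of the 3 values shown sit). For compound 4 the estimate is 25000 nM, with an expected range of 9000 nM to 30000 nM.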

Compound 4, half-maximal effective concentration: 9000 nM
For compound 4 the middle estimate is 2.8-fold (0.44 log units) above the measured one, within the range that was stated.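

Trifluoromethoxy in place of carbamoyl on an aromatic carbon, meta to a large group, gives an at least 2.7-fold lower number from compound 1 to compound 4 (0.44 log units; beyond the scatter) in this assay. Within the data shown here, this is the first sign that a single change at this place on the shared core can move the read-out, and the step's true size stays open on one side. Compound 4 is the only compound shown with a number and not a limit: the limit of > 25000 nM in this assay, at which 3 of the 4 values shown sit.

Among these compounds, with only this one pair, the loss of carbamoyl cannot be separated from the gain of trifluoromethoxy. Going by these compounds, how a methoxy group, a chlorine or an amine at this place would read stays open, as does whether trifluoromethoxy gives a similar step elsewhere on the ring.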